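The compounds below may be only part of what the source reports. "The series", "measured", "known", "first", "only" and "open" are said of these compounds alone.

Measured in a functional assay on A549 cells (Homo sapiens) for antiproliferative activity, read by MTT assay, with a stated time of 48 h; a lower number here means a stronger inhibitor, a higher number a weaker inhibitor:
Compound 1, `COc1ccc(-c2cc3c(cn2)[nH]c(=O)n3-c2cc(OC)c(OC)c(OC)c2)cc1`: compound 1 gives 1120 nM.
Compound 2, `CCOc1ccc(-c2cc3c(cn2)[nH]c(=O)n3-c2cc(OC)c(OC)c(OC)c2)cc1`: compound 2 gives 5300 nM.
Compound 3, `COc1ccc(-c2cc3c(cn2)n(C)c(=O)n3-c2cc(OC)c(OC)c(OC)c2)cc1O`: compound 3 gives 3520 nM.

Compounds 1 and 2 differ in one place: methyl in place of hydrogen on a saturated chain carbon bound to an oxygen on an aromatic ring. That single change produced a 4.7-fold higher number from compound 1 to compound 2 (0.68 log units; beyond the scatter). Compound 3 differs from compound 1 in more than one place; the difference between the two cores is not broken down here. In this assay compound 3 and compound 2 lie within the scatter of each other, while compound 3 sits beyond the scatter from compound 1 with a higher number.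

Compound 4, `CCn1c(=O)n(-c2cc(OC)c(OC)c(OC)c2)c2cc(-c3ccc(OC)c(O)c3)ncc21`, is not yet measured. It differs from compound 3 in one place: methyl in place of hydrogen on a saturated chain carbon bound to an aromatic nitrogen. This is the same kind of change as that from compound 1 to compound 2, not the same change: there the place was on a saturated chain carbon bound to an oxygen on an aromatic ring, here it is on a saturated chain carbon bound to an aromatic nitrogen. Among the compounds with values here, only one measured instance of this kind of change exists among the compounds here, and it lies at a different place, so the expectation is kept smaller and the range wide.

The expected step is a 2.0-fold higher number from compound 3 to compound 4 (0.30 log units; within the scatter), resting on the measured 4.7-fold higher number from compound 1 to compound 2 (0.68 log units; beyond the scatter). For compound 4 the estimate in this assay is 7000 nM, expected to fall between 2500 nM and 20000 nM.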

Compound 4, half-maximal inhibitory concentration: > 20000 nM
Compound 4 ended at the assay's limit; the forecaster's own chance of this, stated with the estimate: 10%; at least 2.8-fold (0.45 log units) between middle value and limit.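

In this assay compound 4 gives > 20000 nM, which is a limit of the assay and not a number. Methyl in place of hydrogen on a saturated chain carbon bound to an aromatic nitrogen, read one bond further out as methyl to ethyl, gives an at least 5.6-fold higher number from compound 3 to compound 4 (0.75 log units; beyond the scatter), so the direction of the step seen on the core of compound 1 also appears on the core of compound 3: the same change on two cores in this assay, a 4.7-fold higher number (0.68 log units; beyond the scatter) from compound 1 to compound 2 and an at least 5.6-fold higher number (0.75 log units; beyond the scatter) from compound 3 to compound 4; the limit leaves it open whether they differ This does not show that the two steps have the same size, nor does a single pair on each core make a rule for the series, and the true size of the new step stays unread with compound 4 at the ceiling: the limit of > 20000 nM in this assay, at which 1 of the 4 values shown sits.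

The compounds shown leave open whether a propyl or longer chain, or an amine or a carboxylic acid carried on the chain at the aromatic nitrogen, would stay at this limit or return to a readable value. They also leave open how much of the gap between the cores of compound 1 and compound 3 belongs to each of the places in which those two compounds differ.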